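The source may hold more compounds than are shown below. What is called first, only, known or untested is meant among the compounds shown, and "the series" means these compounds.

Measured so far:
compound 1 `CN1CCN(c2nc3ccccc3n2CCOc2ccccc2)CC1` — 6.9 nM
compound 2 `CCOCCn1c(N2CCN(C(c3ccccc3)c3ccccc3)CC2)nc2ccccc21` — > 3000 nM; this is a limit of the assay, not a number

Two compounds carry a reading in a functional assay on ileum for inhibition of histamine H1 receptor (Cavia porcellus); a higher number here means a weaker inhibitor, a lower number a stronger inhibitor. Compound 1 gives 6.9 nM and stands as the only true number among the two readings shown. Compound 2 returns only a limit in this assay, so no inhibition number is available for it (the limit of > 3000 nM in this assay, at which 1 of the 2 values shown sits). Among the measured compounds shown here, compounds 1 and 2 differ in more than one place, so no single step connects them; all that can be said is that compound 1 has a measured value and compound 2 does not.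

The compound still to be measured is compound 3 `CCSCCCn1c(N2CCN(C)CC2)nc2ccccc21`. It differs from compound 1 in one place: (ethylsulfanyl)methyl in place of phenoxy on a saturated chain carbon, two bonds along the chain from an aromatic nitrogen. For the measured compounds named here, no step between measured compounds of this kind is available, so the size of the change is guessed rather than derived. The expectation is a step beyond the usual scatter toward weaker inhibition, a 5.8-fold higher number from compound 1 to compound 3 (0.76 log units; beyond the scatter), for compound 3 in this assay. Compound 3 is thus estimated at 40 nM in this assay, with a range from 8 nM to 200 nM.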

Compound 3, half-maximal inhibitory concentration: 530 nM
Compound 3: the middle estimate sits 13-fold (1.12 log units) below what was measured; the measured number lies above the stated range.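

In this assay, the saturated chain carbon two bonds along the chain from an aromatic nitrogen proves sensitive to the group it carries: (ethylsulfanyl)methyl in place of phenoxy gives a 77-fold higher number from compound 1 to compound 3 (1.89 log units; beyond the scatter). Among the compounds shown here, this is the first single-place step, and compound 3 returns a true number of 530 nM. The step combines the loss of the six-membered aromatic ring with the entry of sulfur, and no measured property at hand accounts for its size.

As far as these compounds go, it remains open whether the step follows the loss of the aromatic ring or the exchange of oxygen for sulfur, and phenylsulfanyl or ethoxymethyl in the same place would separate these two changes. Also open, from the compounds shown here alone, is how the shared core would read in this assay with a benzyl group, a longer chain or a terminal amine at this place.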